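Benzyloxy to Methylsulfanyl: Cytotoxicity Expected to Stay at Limit

The source may report more compounds than this note shows. Statements on the series, on what has been measured and on what is new or still open speak of the compounds shown alone.

Compound 1 `COCOc1cccc(C(=O)/C=C/c2ccc3c(c2)B(O)OC3)c1` and compound 2 `O=C(/C=C/c1ccc2c(c1)B(O)OC2)c1ccc(OCc2ccccc2)cc1` share a common core and were both tested in an ADME assay on L929 cells (Mus musculus) for cytotoxicity, read by resazurin assay, with a stated time of 72 h; on this read-out higher numbers stand for weaker inhibition and lower numbers for stronger inhibition. In this assay compound 1 gives > 10 ug/mL, which is a limit of the assay rather than a measured number. In this assay compound 2 likewise gives > 10 ug/mL, again a limit and not a number. Compound 2 therefore stands at the limit of > 10 ug/mL in this assay, at which 2 of the 2 values shown sit, and no order between the two compounds can be read from these values.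

Compound 3 `CSc1ccc(C(=O)/C=C/c2ccc3c(c2)B(O)OC3)cc1` has not yet been measured in this assay. It differs from compound 2 in one place: methylsulfanyl in place of benzyloxy on an aromatic carbon. Going by the values given here, because both values shown sit at the limit of > 10 ug/mL in this assay, at which 2 of the 2 values shown sit, there is no measured step to guide the size of the change to expect. Compound 3 is therefore expected to remain at the limit as well, the expected step being a step that the limit leaves unreadable from compound 2 to compound 3, which is none beyond the usual scatter. Compound 3 is estimated at 15 ug/mL, with a range from 5 ug/mL to 40 ug/mL.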

Compound 3, half-maximal inhibitory concentration: > 10 ug/mL
Compound 3: no number, only a limit; the forecaster's own chance of this, stated with the estimate: 75%; the middle value is on the limit's open side.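

No step can be read from compound 2 to compound 3 in this assay, since both values are limits of the assay and not numbers: the limit of > 10 ug/mL in this assay, at which 3 of the 3 values shown sit.

The compounds shown leave open where each one truly lies beyond that limit, and so whether methylsulfanyl in place of benzyloxy changes the cytotoxicity at all.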